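This account rests on a few compounds, and the source may have more. Where it says the series, first, only, none or still open, it means among the compounds named here.

In a functional assay on Ramos cells (Homo sapiens) for antiproliferative activity, read by CCK-8 assay, with a stated time of 48 h (a lower number here means a stronger inhibitor, a higher number a weaker inhibitor), compound 3 `C=CC(=O)Nc1cccc(-n2cnc3cnc(Nc4ccc(N5CCN(S(C)(=O)=O)CC5)cc4OC)nc32)c1` gives 38600 nM, the higher of the two actual numbers. Compound 1 `C=CC(=O)Nc1cccc(-n2cnc3cnc(Nc4ccc(N5CCN(C)CC5)cc4)nc32)c1` lies clearly lower at 8220 nM. Compound 2 `C=CC(=O)Nc1cccc(-n2cnc3cnc(Nc4ccc(N5CCN(CC)CC5)cc4OC)nc32)c1` reports only a limit, > 40000 nM. Compound 4 `C=CC(=O)Nc1cccc(-n2cnc3cnc(Nc4ccc(N5CCN(C)CC5)cc4OC)nc32)c1` differs from compound 3 by a single change, methyl in place of methylsulfonyl on an amine nitrogen in a ring. Within the data shown here, the one measured step at that nitrogen is an at least 1.0-fold lower number from compound 2 to compound 3 (0.01 log units; that floor lies within the scatter), with methylsulfonyl in place of ethyl; it rests on a limit and so gives only a floor. Compound 4 carries the same 4-methylpiperazin-1-yl group as compound 1, which shows 8220 nM, but the two differ elsewhere in the structure. A modest fall in the number is therefore expected, not clearly beyond the scatter, and the estimated step is a 1.8-fold lower number from compound 3 to compound 4 (0.24 log units; within the scatter). The expected value for compound 4 is 22000 nM, with an estimated range of 8000 nM to 48000 nM.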

Compound 4, half-maximal inhibitory concentration: 13200 nM
Compound 4: middle estimate off by 1.7-fold (0.22 log units), on the high side; measured number inside the range.
By their numbers in this assay, from the lowest: compounds 1 and 4 (each within the scatter of the next); then compound 3. At a limit, above all of these: compound 2.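

In this assay, the change on the ring nitrogen now gives a step beyond the scatter: methyl in place of methylsulfonyl gives a 2.9-fold lower number from compound 3 to compound 4 (0.47 log units; beyond the scatter), whereas the earlier step at that nitrogen gave only a floor within the scatter. Methoxy in place of hydrogen on an aromatic carbon gives a 1.6-fold higher number from compound 1 to compound 4 (0.21 log units; within the scatter), so with methyl on that nitrogen, this change shows no readable effect. Methyl in place of ethyl at the same nitrogen gives an at least 3.0-fold lower number from compound 2 to compound 4 (0.48 log units; beyond the scatter), which is only a floor, as compound 2 is reported as a limit and not a number: the limit of > 40000 nM in this assay, at which 1 of the 4 values shown sits.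

The compounds shown leave open how the number would read with hydrogen or an acetyl group on that nitrogen. They also leave open whether methoxy matters when methylsulfonyl or ethyl sits there.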